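The source may report more compounds than this note shows. Statements on the series, on what has been measured and on what is new or still open speak of the compounds shown alone.

Working notes on the series. Compound 1 `NC(=O)c1cccc(-c2cnc(C(=O)CCCCCCc3ccccc3)o2)c1` carries a 3-carbamoylphenyl on the shared core, compound 2 `Cc1ccnc(-c2cnc(C(=O)CCCCCCc3ccccc3)o2)c1` a 4-methylpyridin-2-yl and compound 3 `COc1ccnc(-c2cnc(C(=O)CCCCCCc3ccccc3)o2)c1` a 4-methoxypyridin-2-yl. In an assay (Rattus norvegicus) for inhibition of Fatty-acid amide hydrolase 1 (Homo sapiens) (on this read-out lower numbers stand for stronger inhibition and higher numbers for weaker inhibition), compound 1 gives 2700 nM, compound 2 gives 1 nM and compound 3 gives 1.7 nM. The exchange of the whole aryl group is the only large move recorded: a 2700-fold lower number from compound 1 to compound 2 (3.43 log units; beyond the scatter) and a 1600-fold lower number from compound 1 to compound 3 (3.20 log units; beyond the scatter). Within the pyridine pair the move is small: a 1.7-fold higher number from compound 2 to compound 3 (0.23 log units; within the scatter). Compound 3 therefore stands second highest of the three numbers, nearest to compound 2 and far from compound 1.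

Compound 4 `O=C(CCCCCCc1ccccc1)c1ncc(-c2cc(C(F)(F)F)ccn2)o1` differs from compound 3 in one place: trifluoromethyl in place of methoxy on an aromatic carbon. For the measured compounds named here, no measured step covers a trifluoromethyl group. Going by the values given here, the only step at this position, from methyl to methoxy, stays within the scatter, and both pyridine compounds give low numbers. The working expectation for this assay is accordingly a step in either direction that is not clearly beyond the scatter, with the range widened because no group of this kind has been measured on the ring. Compound 4 is expected to give 3 nM, between 0.8 nM and 15 nM. The estimate means a 1.8-fold higher number from compound 3 to compound 4 (0.25 log units; within the scatter).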

Compound 4, half-maximal inhibitory concentration: 1.5 nM
The estimate for compound 4 lay 2.0-fold (0.30 log units) above the measured number; measured number inside the range.
By their numbers in this assay, from the lowest: compounds 2, 4 and 3 (each within the scatter of the next); then compound 1.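

In this assay a third group on the aromatic carbon opposite the ring nitrogen brings no separation: trifluoromethyl in place of methoxy gives a 1.1-fold lower number from compound 3 to compound 4 (0.05 log units; within the scatter) and trifluoromethyl in place of methyl gives a 1.5-fold higher number from compound 2 to compound 4 (0.18 log units; within the scatter), so all three pyridine compounds lie within the scatter of one another. The earlier compounds shown here covered only methyl and methoxy here, whereas compound 4 carries a group of 4 heavy atoms with 0 hydrogen-bond acceptors in place of the 2 heavy atoms and 1 hydrogen-bond acceptor of methoxy, and its number remains in the same low range. No measurement available here bears on why these groups read alike.

Still open, from the compounds shown here alone, is whether this insensitivity extends to an amine, a carboxylic acid or a longer alkoxy chain on the same carbon. Also open, going by these compounds, is how much of the large gap to compound 1 belongs to the ring nitrogen and how much to the carbamoyl group, since that exchange replaces the whole aryl group and a plain phenyl or unsubstituted pyridin-2-yl on the shared core would be needed to separate them.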